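Compound 4 from compound 1: fluoro for hydrogen

The source may hold more compounds than are shown below. What is called first, only, known or untested is meant among the compounds shown, and "the series" means these compounds.

Compound 1 `[N-]=[N+]=Nc1cc(=O)[nH]c(=O)n1[C@@H]1O[C@H](CO)[C@@H](O)[C@H]1O` is the reference point of the series. In a functional assay on OVCAR-4 cells (Homo sapiens) for antiproliferative activity, read by WST assay, with a stated time of 3 days (on this read-out lower numbers stand for stronger inhibition and higher numbers for weaker inhibition), compound 1 gives > 50000 nM, which is a limit of the assay and not a number. Compound 2 `COC(=O)c1cc(=O)[nH]c(=O)n1[C@@H]1O[C@H](CO)[C@@H](O)[C@H]1O` gives > 50000 nM in this assay, again only a limit. Compound 3 `CNc1cc(=O)[nH]c(=O)n1[C@@H]1O[C@H](CO)[C@@H](O)[C@H]1O` gives > 50000 nM in this assay, also a limit. Compound 1 thus stands at the limit of > 50000 nM in this assay, at which 3 of the 3 values shown sit, together with the two other values shown. The steps a step that the two limits leave unreadable from compound 1 to compound 2, a step that the two limits leave unreadable from compound 1 to compound 3 and a step that the two limits leave unreadable from compound 2 to compound 3 remain unreadable. Compound 4 `[N-]=[N+]=Nc1c(F)c(=O)[nH]c(=O)n1[C@@H]1O[C@H](CO)[C@@H](O)[C@H]1O` differs from compound 1 by fluoro in place of hydrogen on an aromatic carbon. Within the data shown here, no measured step bears on this change, and no step beyond the scatter is expected in this assay. Compound 4 is expected at 60000 nM, between 20000 nM and 200000 nM, meaning a step that the limit leaves unreadable from compound 1 to compound 4.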

Compound 4, half-maximal inhibitory concentration: 1500 nM
Compound 4: middle estimate off by 40-fold (1.60 log units), on the high side; measured number below the stated range.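

Fluoro in place of hydrogen on the aromatic carbon ortho to the azido group gives an at least 33-fold lower number from compound 1 to compound 4 (1.52 log units; beyond the scatter) in this assay, the first readable step in the series. The steps among compound 1, compound 2 and compound 3 cannot be read, so the group ortho to this carbon gave no readable effect, whereas this carbon does. Compound 4 is the only compound shown with a number rather than a limit: the limit of > 50000 nM in this assay, at which 3 of the 4 values shown sit.

Open, as far as these compounds go, is whether chloro, methyl or an amine on this carbon would match fluoro. Also open, from the compounds shown here alone, is whether fluoro gives a similar step with methylamino or methoxycarbonyl in place of azido.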